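The source may report more compounds than this note shows. Statements on the series, on what has been measured and on what is new or still open speak of the compounds shown alone.

Compound 1 `N#Cc1cnc(NCc2cnccc2C(F)(F)F)cc1NC[C@H]1C[C@@H](O)C1` is the reference point of this account. In an assay on isolated protein for inhibition of protein kinase C delta type (Homo sapiens), read by TR-FRET, with a stated time of 2 h (a higher number here means a weaker inhibitor, a lower number a stronger inhibitor), compound 1 gives 4200 nM, the highest of the two numbers reported; its nearest neighbour is compound 3 `CC1(C)C[C@H](Nc2nc(NCc3cnccc3C(F)(F)F)ncc2C#N)CC[C@@H]1O`, which gives 800 nM, a gap that lies beyond the usual scatter. For compound 2 `N#Cc1cnc(NCc2ccccc2C(F)(F)F)cc1N[C@H]1CC[C@H](O)CC1` the result in this assay is a limit and not a number, > 10000 nM, the case described by the limit of > 10000 nM in this assay, at which 1 of the 3 values shown sits. Compound 4 `CC1(C)[C@@H](Nc2cc(NCc3cnccc3C(F)(F)F)ncc2C#N)C[C@H]1C(N)=O` has not yet been measured. It differs from compound 1 in one place: 3-carbamoyl-2,2-dimethylcyclobutyl in place of (3-hydroxycyclobutyl)methyl on a nitrogen on an aromatic ring. No step between two measured compounds matches this change, so its size can only be inferred from the compounds shown. Among the compounds with values here, compound 3 gives 800 nM and is the only compound that sits clearly below compound 1, which suggests that a different saturated ring on that nitrogen need not cost potency. A modest downward step is expected, a 2.8-fold lower number from compound 1 to compound 4 (0.45 log units; beyond the scatter). Compound 4 is estimated at 1500 nM, with a range from 400 nM to 6000 nM.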

Compound 4, half-maximal inhibitory concentration: 4500 nM
For compound 4 the middle estimate is 3.0-fold (0.48 log units) below the measured one, within the range that was stated.
By their numbers in this assay, from the lowest: compound 3; then compounds 1 and 4 (each within the scatter of the next). At a limit, above all of these: compound 2.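

In this assay, within the data shown here, the first measured step at this nitrogen reads a 1.1-fold higher number from compound 1 to compound 4 (0.03 log units; within the scatter), so the two groups cannot be told apart here. The exchange of (3-hydroxycyclobutyl)methyl for 3-carbamoyl-2,2-dimethylcyclobutyl sets the four-membered ring directly on the nitrogen, replaces the hydroxyl with a carbamoyl group and adds two methyl groups, yet the result stays within the scatter. Nothing given here on the compounds bears on this outcome.

Among these compounds, the single step combines these changes, so it remains open whether the carbamoyl group, the two methyl groups or the loss of the methylene link would matter if changed alone, or whether their contributions offset one another. Also open, going by these compounds, is how a primary amine or a carboxylic acid in place of the carbamoyl group on the same ring would read in this assay.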